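From 2-fluorophenyl to 4-chlorophenyl in compound 1

The source may report more compounds than this note shows. Statements on the series, on what has been measured and on what is new or still open speak of the compounds shown alone.

Of the compounds shown here, two have been measured so far in a functional assay on microsomes for inhibition, with a stated time of 1 h; a lower number here means a stronger inhibitor, a higher number a weaker inhibitor. Compound 1 (`CCOC(=O)c1cnn(-c2nc(-c3ccccc3F)c(C#N)c(=O)n2C)c1N`) gives 94 ug/mL and holds the higher of the two numbers. Compound 2 (`CSc1nc(-c2cccc(O)c2O)c(C#N)c(=O)n1C`) gives 41 ug/mL and lies lower than compound 1 by more than the usual scatter. Among the measured compounds shown here, these two differ in more than one place, and no measured pair isolates a single change. Compound 3 (`CCOC(=O)c1cnn(-c2nc(-c3ccc(Cl)cc3)c(C#N)c(=O)n2C)c1N`) keeps the rest of compound 1 and carries 4-chlorophenyl in place of 2-fluorophenyl on an aromatic carbon. With compound 1 at 94 ug/mL as the only close reference, no step beyond the scatter is expected in this assay and no direction can be favoured with confidence. The estimated change is a 1.2-fold lower number from compound 1 to compound 3 (0.07 log units; within the scatter) and remains small. Compound 3 is expected at 80 ug/mL with an estimated range of 33 ug/mL to 190 ug/mL in this measurement.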

Compound 3, half-maximal inhibitory concentration: 88 ug/mL
Estimate against measurement, compound 3: 1.1-fold (0.04 log units) below, and the stated range covers the measured number.
By their numbers in this assay, from the lowest: compound 2; then compounds 3 and 1 (each within the scatter of the next).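

Read in this assay the step of a 1.1-fold lower number from compound 1 to compound 3 (0.03 log units; within the scatter) lies within the usual scatter and is the first comparison that isolates one place, the aromatic carbon ortho to a cyano group. At this position, on the core of compound 1, the assay does not distinguish 2-fluorophenyl from 4-chlorophenyl, although the halogen and its location on the phenyl ring differ between the two groups. Nothing available explains this result or links it to a property of either group.

The compounds shown do not separate the identity of the halogen from its location on the phenyl ring. They also leave open whether a phenyl ring bearing an amine or a carboxylic acid, or a saturated ring such as cyclohexyl in place of the phenyl, would give a step beyond the scatter at this position.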